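The source may hold more compounds than are shown below. What is called first, only, known or untested is meant among the compounds shown, and "the series" means these compounds.

Measured compounds:
- Compound 1 `COc1ccc(/C(Cl)=C/C=C(\C#N)C(=O)c2c[nH]c3ccccc23)cc1` gives 61.3%
- Compound 2 `Cc1[nH]c2ccccc2c1C(=O)/C(C#N)=C/C=C(\Cl)c1ccc(Br)cc1` gives 69.1%
- Compound 3 `COc1cc(/C(Cl)=C/C=C(\C#N)C(=O)c2c[nH]c3ccc(Br)cc23)cc(OC)c1OC` gives 50%

All three were tested in a functional assay for inhibition, with a stated time of 5 min, tested at 1 mM; on this read-out lower numbers stand for less inhibition and higher numbers for more inhibition at the one concentration tested (going by the name of the read-out). Compound 1 stands second highest of the three numbers; its reading and that of compound 2 lie within the usual scatter of each other, while compound 3 sits beyond the scatter below compound 1. No two of these compounds differ in only one place, so no single change can be read off from the measured set.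

Compound 4 `COc1ccc(/C(Cl)=C/C=C(\C#N)C(=O)c2c[nH]c3ccccc23)cc1OC` differs from compound 1 in one place: methoxy in place of hydrogen on an aromatic carbon. Going by the values given here, with no measured step of this kind to lean on, the expected change is small, if any, and likely not beyond the scatter; the estimated step is a number 4.3 percentage points lower from compound 1 to compound 4 (within the scatter). Compound 4 is expected to give about 57%, in a range from 40% to 72%.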

Compound 4, a percentage reported as inhibition, at one concentration (the size of the read-out at that concentration, not a potency): 63.6%
Compound 4: middle estimate off by 6.6 percentage points, on the low side, within the range that was stated.
By their numbers in this assay, from the lowest: compound 3; then compounds 1, 4 and 2 (each within the scatter of the next).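

In this assay, going by these compounds alone, the step is a number 2.3 percentage points higher from compound 1 to compound 4 (within the scatter) for methoxy in place of hydrogen, the first single-place comparison in this set. On this aromatic carbon, ortho to a methoxy group and meta to a large group, the added methoxy therefore brings no change that can be told from scatter at the one concentration tested. No measurement here bears on the reason for this result. Still open, from the compounds shown here alone, is whether an amine or a carboxylic acid on this same carbon would leave the reading equally unchanged. Going by these compounds, a longer chain there is equally open.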